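Moving a chloro group around the urea phenyl ring

A few compounds are considered here, and "the series" means these few. Any claim that something is new, unique, unknown or untested is made for them only; others in the source may bear on it.

The compounds here share one core, varying only the phenyl ring on the far side of the urea. Compound 1 `Cc1cc(OCc2nc3ccccc3s2)ccc1NC(=O)Nc1ccccc1` carries a plain phenyl there and gives 730 nM in an assay on isolated protein for inhibition of Polyunsaturated fatty acid 5-lipoxygenase (Homo sapiens), read by HPLC, with a stated time of 10 min; on this read-out lower numbers stand for stronger inhibition and higher numbers for weaker inhibition. Compound 2 `Cc1cc(OCc2nc3ccccc3s2)ccc1NC(=O)Nc1ccccc1Cl` carries a chloro on that ring and gives 830 nM in this assay. Against compound 1, compound 2 stands within the usual scatter, as the step of a 1.1-fold higher number from compound 1 to compound 2 (0.06 log units; within the scatter) shows, so the two cannot be ranked on these numbers.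

Compound 3 `Cc1cc(OCc2nc3ccccc3s2)ccc1NC(=O)Nc1cccc(Cl)c1` is not yet measured. It differs from compound 2 by 3-chlorophenyl in place of 2-chlorophenyl on an amide-type nitrogen. Among the compounds with values here, no measured step moves a chloro from one ring position to another; the only bearing step, from compound 1 to compound 2, added the chloro and changed little. A step of about a 1.2-fold lower number from compound 2 to compound 3 (0.07 log units; within the scatter) is therefore expected, with no clear direction. Compound 3 is estimated at 700 nM, within 300 nM to 1700 nM.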

Compound 3, half-maximal inhibitory concentration: 160 nM
For compound 3 the middle estimate is 4.4-fold (0.64 log units) above the measured one; the measured number lies below the stated range.
By their numbers in this assay, from the lowest: compound 3; then compounds 1 and 2 (each within the scatter of the next).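

The place of the chloro on the ring turns out to matter, even though the two groups have the same atoms: 3-chlorophenyl in place of 2-chlorophenyl on the amide-type nitrogen gives stronger inhibition in this assay (a 5.2-fold lower number from compound 2 to compound 3 (0.71 log units; beyond the scatter)). Adding a chloro can therefore help, as the plain phenyl of compound 1 also shows (a 4.6-fold lower number from compound 1 to compound 3 (0.66 log units; beyond the scatter)), whereas the 2-chlorophenyl of compound 2 gave no readable change from that plain phenyl. Nothing available explains why one placement differs from the other.

On these data alone, whether the gain belongs to chloro itself remains open, since a bromo, methoxy or trifluoromethyl group at the same place on the ring could give a different result. As far as these compounds go, whether a second chloro on that ring would add to the gain also remains unknown.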